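Swapping the aryl group before the cytotoxicity read

The source may hold more compounds than are shown below. What is called first, only, known or untested is meant among the compounds shown, and "the series" means these compounds.

In an ADME assay on A549 cells (Homo sapiens) for cytotoxicity, read by CellTiter-Glo (on this read-out higher numbers stand for lower toxicity in this test and lower numbers for higher toxicity in this test), compound 3 `Cc1c(Cc2ccc(OC(F)(F)F)cc2)c(=O)oc2cc(OCC(O)CN3CCC(C(N)=O)CC3)ccc12` gives 68200 nM, the highest of the two numbers at hand. Compound 1 `COc1ccc(Cc2c(C)c3ccc(OCC(O)CN4CCC(C(N)=O)CC4)cc3oc2=O)c(Br)c1` gives 44400 nM in this assay. Compound 2 `Cc1c(Cc2ccccc2C(F)(F)F)c(=O)oc2cc(OCC(O)CN3CCC(C(N)=O)CC3)ccc12` reaches only the limit of this assay, > 100000 nM. The step of a 1.5-fold higher number from compound 1 to compound 3 (0.19 log units; within the scatter) and the step of an at least 1.4-fold lower number from compound 2 to compound 3 (0.16 log units; that floor lies within the scatter) both exchange the aryl group on the saturated chain carbon, and neither stands beyond the scatter. Compound 4 `Cc1c(Cc2ccc(-c3ccc(F)cc3)cc2)c(=O)oc2cc(OCC(O)CN3CCC(C(N)=O)CC3)ccc12` differs from compound 3 by 4-fluorophenyl in place of trifluoromethoxy on an aromatic carbon. The earlier exchanges of that aryl group moved this assay little, so for compound 4 no shift beyond the scatter is expected in this assay. Compound 4 is therefore estimated at 60000 nM, with a range from 28000 nM to 130000 nM. The expected step is a 1.1-fold lower number from compound 3 to compound 4 (0.06 log units; within the scatter).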

Compound 4, half-maximal cytotoxic concentration: 19300 nM
Beside the measured number, compound 4's estimate is 3.1-fold (0.49 log units) above it, and the stated range ends above it.
By their numbers in this assay, from the lowest: compound 4; then compounds 1 and 3 (each within the scatter of the next). At a limit, above all of these: compound 2.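

In this assay the step of a 3.5-fold lower number from compound 3 to compound 4 (0.55 log units; beyond the scatter) is the first move beyond the scatter towards a lower number among these compounds, which here means higher toxicity in this test. It shows that the read-out responds to a change on an aromatic carbon para to a large group, where 4-fluorophenyl brings in a six-membered aromatic ring of carbon only. Nothing given here explains this step. As far as these compounds go, it remains open whether the ring or its fluorine carries the step, and what an unsubstituted phenyl, a morpholine or a carboxylic acid would give at this place.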